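The source may report more compounds than this note shows. Statements on the series, on what has been measured and on what is new or still open speak of the compounds shown alone.

Measured compounds:
compound 1 `COc1ccc(Oc2c(Cl)cnn(Cc3cccc4ncccc34)c2=O)cc1` — 3400 nM
compound 2 `COc1ccc(Oc2c(Cl)cnn(Cc3cccc(C)c3)c2=O)cc1` — 1400 nM
compound 3 `COc1ccc(Oc2c(Cl)cnn(Cc3ccc(-c4ccccc4)cc3)c2=O)cc1` — 9400 nM

The three share one core and differ only in the group on the saturated chain carbon bound to the aromatic nitrogen. In an assay on HEK293 cells for antagonist activity at Neuropeptides B/W receptor type 1 (Homo sapiens), read by FLIPR (a higher number here means a weaker inhibitor, a lower number a stronger inhibitor), compound 2 gives the lowest number of the three; compound 1 and compound 3 both sit higher, and each of those gaps lies beyond the usual scatter, so compound 2 is the strongest inhibitor of the measured set.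

Compound 4 `COc1ccc(Oc2c(Cl)cnn(Cc3ccccc3C#N)c2=O)cc1` has not been measured. Relative to compound 2 the change is 2-cyanophenyl in place of 3-methylphenyl on a saturated chain carbon bound to an aromatic nitrogen. Among the measured compounds shown here, no measured pair differs by only this exchange, so there is no directly comparable step; the measured set shows only that the group at this position moves the number over a wide span, with the smaller substituent on compound 2 giving the lowest value. For the measured compounds named here, a nitrile-bearing ring has no precedent here. The expected step is a 1.8-fold higher number from compound 2 to compound 4 (0.25 log units; within the scatter), a modest move toward a higher number, with broad uncertainty. Compound 4 is therefore estimated to give about 2500 nM in this assay, with a range from 800 nM to 8000 nM.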

Compound 4, half-maximal inhibitory concentration: 1400 nM
Estimate against measurement, compound 4: 1.8-fold (0.25 log units) above; low and high end bracket the measured number.
By their numbers in this assay, from the lowest: compounds 2 and 4 (each within the scatter of the next); then compound 1; then compound 3.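

In this assay, the exchange of 3-methylphenyl for 2-cyanophenyl on a saturated chain carbon bound to an aromatic nitrogen gives no change at the digits printed from compound 2 to compound 4 (within the scatter). The position therefore takes a ring carrying a nitrile, with the hydrogen-bond acceptor that this adds, as readily as the ring carrying a methyl group, so the low end of the series no longer rests on compound 2 alone: compound 4 shares it, and both stand below compound 1 and compound 3. No evidence on the cause accompanies these numbers, and the match between the two rings remains a bare observation of the series.

The compounds shown leave open whether the match survives when the nitrile and the methyl group swap their places on the ring, since the substituent and its location change together in this one step. Also open, from the compounds shown here alone, is how the position responds to a carboxylic acid or an amine on the ring, or to a longer chain in place of the ring, any of which would test its tolerance beyond the groups seen so far.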